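A few compounds are considered here, and "the series" means these few. Any claim that something is new, unique, unknown or untested is made for them only; others in the source may bear on it.

In a functional assay on the whole organism for antagonist activity, with Mus musculus as the target (a higher number here means that more compound is needed for the effect, a lower number that less compound is needed), compound 1 `CCSc1nnc(-c2ccccc2)n1C` reaches only the limit of the assay, > 200 mg/kg. Compound 2 `CCSc1nnc(-c2ccccc2F)n1C`, in this assay, gives 18.6 mg/kg. The one difference between them is fluoro in place of hydrogen on an aromatic carbon, and that change makes an at least 10-fold lower number from compound 1 to compound 2 (1.03 log units; beyond the scatter).

Compound 3 `Cn1nc(-c2ccccc2)nc1S(C)(=O)=O` likewise gives only a limit of the assay in this assay, > 200 mg/kg. How the core of compound 3 differs from the core of compound 1 is not broken down here. For the measured compounds named here, two of the three values so far sit at the same limit (the limit of > 200 mg/kg in this assay, at which 2 of the 3 values shown sit).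

Compound 4 `Cn1nc(-c2cccc(F)c2)nc1S(C)(=O)=O` has not yet been measured in this assay. It differs from compound 3 by fluoro in place of hydrogen on an aromatic carbon. Going by the values given here, this is the same kind of change as the one from compound 1 to compound 2, though not the same: in compound 2 the fluoro sits ortho to a group of 9 heavy atoms, whereas in compound 4 it sits meta to a large group, and the two pairs rest on different cores.

On that footing the author expects the step from compound 3 to compound 4 to be an at least 2.5-fold lower number from compound 3 to compound 4 (0.39 log units; beyond the scatter), set beside an at least 10-fold lower number from compound 1 to compound 2 (1.03 log units; beyond the scatter) for the measured pair, with much uncertainty since compound 3 itself sits only at a limit. For compound 4 in this assay the author estimates 80 mg/kg, within a range from 15 mg/kg to 250 mg/kg.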

Compound 4, dose for half-maximal effect: > 100 mg/kg
Compound 4: a limit, no number (the forecaster's own chance of this, stated with the estimate: 50%); middle value at least 1.2-fold (0.09 log units) away from the limit.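

In this assay compound 3 and compound 4 both give only limits of the assay, not numbers, so the step between them cannot be read. The compounds shown leave open whether fluoro in place of hydrogen on an aromatic carbon, on the core of compound 3, changes the number at all, or whether it gives anything like an at least 10-fold lower number from compound 1 to compound 2 (1.03 log units; beyond the scatter).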